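The compounds below may be only part of what the source reports. "The series", "measured", "known", "first", "only" and "open" are said of these compounds alone.

Measured so far in a functional assay on KB 3-1 cells (Homo sapiens) for cytotoxicity, read by MTT assay, with a stated time of 72 h; a higher number here means a weaker inhibitor, a lower number a stronger inhibitor
compound 1 `O=C1Nc2ccccc2/C1=N/NC(=S)Nc1cccc2ccccc12` gives 5120 nM
compound 2 `O=C1Nc2ccccc2/C1=N/NC(=S)Nc1ccc2c(c1)CCC2` gives 5800 nM
compound 3 `O=C1Nc2ccccc2/C1=N/NC(=S)NCc1ccccc1` gives 11700 nM

Compound 3 (11700 nM) lies within the usual scatter of compound 2 (5800 nM). Its number is higher, beyond the scatter, than that of compound 1 (5120 nM), so it is a weaker inhibitor than compound 1 in this assay but cannot be told apart from compound 2.

The next compound to consider is compound 4 `CNC(=S)N/N=C1\C(=O)Nc2ccccc21`. It keeps the shared core and differs from compound 3 in one place: hydrogen in place of phenyl on a saturated chain carbon bound to an amide-type nitrogen. Cut one bond further out, the same difference reads benzyl to methyl.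

For the measured compounds named here, no two measured compounds differ in only one place, so there is no direct step to borrow as a guide. However, each of the three measured compounds has an aromatic ring in this part of the molecule, and compound 4 has none. A moderate move towards a higher number is therefore expected, starting from compound 3 (11700 nM). The expected rise a 2.1-fold higher number from compound 3 to compound 4 (0.33 log units; beyond the scatter) would mean a weaker inhibitor, though this rests on very little data. The estimated value for compound 4 is 25000 nM (expected range 10000 nM to 60000 nM).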

Compound 4, half-maximal inhibitory concentration: 35300 nM
Estimate against measurement, compound 4: 1.4-fold (0.15 log units) below; the measured number falls inside the stated range.
By their numbers in this assay, from the lowest: compounds 1, 2 and 3 (each within the scatter of the next, the first and the last beyond it); then compound 4.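

Taking away the phenyl, so that benzyl becomes methyl, gives a 3.0-fold higher number from compound 3 to compound 4 (0.48 log units; beyond the scatter) in this assay and is the first change at a single place that can be read in this series. For the compounds shown here, it shows that the group on a saturated chain carbon bound to an amide-type nitrogen affects the number, which the earlier compounds could not show, as no two of them differ in only one place; the step is modest, and without the phenyl compound 4 still gives a measured 35300 nM in this assay. Nothing measured here explains why the number rises on this change.

The compounds shown leave open whether the rise goes with the loss of the aromatic ring itself or simply with a smaller group, and a propyl chain, with no ring but more carbon than methyl, would help separate the two. Also open, from the compounds shown here alone, is how the number would respond to a benzyl group carrying an amine or a carboxylic acid on its ring, and one step alone cannot establish a trend.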